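A few compounds are considered here, and "the series" means these few. Any claim that something is new, unique, unknown or untested is made for them only; others in the source may bear on it.

Compound 1 `CN(C)CCN1CCN(CC(=O)Nc2ccc(-c3nc4cc(Cl)ccc4o3)cc2)CC1`, compound 2 `Cc1cc(-c2nc3cc(Cl)ccc3o2)ccc1NC(=O)CN1CCN(CCN(C)C)CC1` and compound 3 `Cc1cc(-c2nc3ccccc3o2)ccc1NC(=O)CN1CCN(CCCN(C)C)CC1` were tested in a functional assay on MCF7 cells (Homo sapiens) for cytotoxicity, read by MTT assay, with a stated time of 24 h; a higher number here means a weaker inhibitor, a lower number a stronger inhibitor. Compound 1 gives 7920 nM, compound 2 gives 39300 nM, and compound 3 gives 11300 nM. Compound 2 and compound 1 differ in one place only, (hydrogen in place of methyl on an aromatic carbon), and this step gives a 5.0-fold lower number from compound 2 to compound 1 (0.70 log units; beyond the scatter). Compound 3 and compound 2 differ by more than one change, and the difference between the two cores is not broken down here; their values show compound 3 with the lower number of the two.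

Compound 4 `CN(C)CCCN1CCN(CC(=O)Nc2ccc(-c3nc4ccccc4o3)cc2)CC1` has not yet been measured in this assay. It differs from compound 3 by hydrogen in place of methyl on an aromatic carbon. This is the same kind of change as that from compound 2 to compound 1, but the surroundings are not identical: in compound 2 the place lies meta to a 5-chloro-1,3-benzoxazol-2-yl group, whereas in compound 3 it lies meta to a 1,3-benzoxazol-2-yl group. Because the earlier step gave a 5.0-fold lower number from compound 2 to compound 1 (0.70 log units; beyond the scatter), a step of similar direction, a 3.8-fold lower number from compound 3 to compound 4 (0.58 log units; beyond the scatter), is expected from compound 3 to compound 4. Compound 4 is therefore estimated at 3000 nM, within a range from 900 nM to 10000 nM.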

Compound 4, half-maximal inhibitory concentration: 23400 nM
Compound 4: the middle estimate sits 7.8-fold (0.89 log units) below what was measured, outside the stated range (above it).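

In this assay, hydrogen in place of methyl on the aromatic carbon gives a 2.1-fold higher number from compound 3 to compound 4 (0.32 log units; beyond the scatter), so the lower number seen on the core of compound 2 does not recur on the core of compound 3. Set beside each other, the two steps point in opposite directions, and the earlier step cannot be carried to the other core as a fixed increment in this series: the same change on two cores in this assay, a 5.0-fold lower number (0.70 log units; beyond the scatter) from compound 2 to compound 1 and a 2.1-fold higher number (0.32 log units; beyond the scatter) from compound 3 to compound 4, 10-fold (1.01 log units) apart, beyond the scatter of two such steps. This does not show which difference between the cores matters, as the pairs differ both in the 5-chloro-1,3-benzoxazol-2-yl group against the 1,3-benzoxazol-2-yl group and in the length of the dimethylamino side chain, and two pairs cannot support a general rule.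

The compounds shown leave open whether the direction of the step follows the chlorine or the side chain, as these two features change together here. They also leave open how an ethyl or a methoxy group in place of the methyl would read on either core.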